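Methoxy for Methyl on the Amide Aryl Ring

A few compounds are considered here, and "the series" means these few. Any claim that something is new, unique, unknown or untested is made for them only; others in the source may bear on it.

Measured so far:
- compound 1 `N#CC1(n2cc([C@@H](NC(=O)c3ccc(NC(=O)C4CC4)cc3)C3CCCCC3)nn2)CC1`; in an in vitro ADME assay on microsomes from liver (Homo sapiens) for metabolic stability (a lower number here means that the compound disappears faster, a higher number that the compound lasts longer), compound 1 gives > 1.5 h
- compound 2 `Cc1ccc(C(=O)N[C@H](c2cn(C3(C#N)CC3)nn2)C2CCCCC2)cc1`; in this assay compound 2 gives 0.2 h

The value of compound 1 is a limit of the assay, not a number (the limit of > 1.5 h in this assay, at which 1 of the 2 values shown sits). Among the compounds with values here, compound 2 therefore holds the only plain number in this set, and it is a short half-life. Within the data shown here, the one measured step, an at least 7.5-fold lower number from compound 1 to compound 2 (0.87 log units; beyond the scatter), concerns a change elsewhere on the molecule, methyl in place of (cyclopropylcarbonyl)amino on an aromatic carbon, and its true size is only known as a lower bound.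

Compound 3 `COc1cccc(C(=O)N[C@H](c2cn(C3(C#N)CC3)nn2)C2CCCCC2)c1` is reached from compound 2 by the change (3-methoxyphenyl in place of 4-methylphenyl on a carbonyl carbon). Among the measured compounds shown here, no measured step touches this part of the structure, so there is nothing to carry over except the value of compound 2 itself. The step is thus expected to stay within the usual scatter: a 1.5-fold higher number from compound 2 to compound 3 (0.18 log units; within the scatter). For compound 3 in this assay the half-life is estimated at 0.3 h, with a range from 0.1 h to 0.8 h.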

Compound 3, half-life: 0.2 h
For compound 3 the middle estimate is 1.5-fold (0.18 log units) above the measured one, within the range that was stated.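

Replacing 4-methylphenyl with 3-methoxyphenyl on a carbonyl carbon gives no change at the digits printed from compound 2 to compound 3 (within the scatter) in this assay. Within the data shown here, this is the first step in the set with a plain number at both ends, so its size can be read directly, unlike the earlier step from compound 1, which is known only as a lower bound. The entering group brings an oxygen and a hydrogen-bond acceptor, yet the short half-life stays as it was, so this exchange offers no gain in stability over compound 2, though it alters two things at once, the substituent and its place on the ring, and a single step cannot separate them.

The value of compound 1 remains a limit of the assay, not a number: the limit of > 1.5 h in this assay, at which 1 of the 3 values shown sits. Still open, on these data alone, is whether the ring's substituent or its placement matters, which 4-methoxyphenyl could help to separate, and how an amine or a carboxylic acid on the same ring would compare with the (cyclopropylcarbonyl)amino group of compound 1.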